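The compounds below may be only part of what the source reports. "The series", "measured", "known", "first", "only" and "open" are said of these compounds alone.

For the measured compounds named here, compound 1 `CC(C)NC(=O)CC(c1ccc(-c2ccc3cccc(F)c3c2)[nH]c1=O)C(C)C` is one of three compounds measured so far in an ADME assay on microsomes from liver (Rattus norvegicus) for metabolic stability; on this read-out higher numbers stand for a longer-lived compound and lower numbers for a shorter-lived compound. In this assay compound 1 gives only a limit of the assay, < 0.0667 h, so its standing among the others is known only through (the limit of < 0.0667 h in this assay, at which 1 of the 3 values shown sits). Compound 2 `CC(C)[C@H](C[C@H]1CCNC1=O)c1ccc(-c2ccc3cccc(F)c3c2)[nH]c1=O` gives 0.227 h in this assay, and compound 3 `CC(C)C(c1cnc(N)s1)c1ccc(-c2ccc3cccc(F)c3c2)[nH]c1=O` gives 0.0983 h.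

Compound 4 `Cc1c[nH]c(C(c2ccc(-c3ccc4cccc(F)c4c3)[nH]c2=O)C(C)C)n1` has not yet been measured. It differs from compound 1 in one place: 4-methyl-1H-imidazol-2-yl in place of (isopropylcarbamoyl)methyl on a saturated chain carbon bound to an aromatic carbon and a saturated chain carbon. Going by the values given here, the one measured step that bears on this change is an at least 1.4-fold higher number from compound 1 to compound 3 (0.16 log units; that floor lies within the scatter), where the same group on the same saturated chain carbon is exchanged for another aromatic group. That step is only a floor and lies within the scatter, so no shift beyond the scatter can be counted on for compound 4. Guided by compound 3 and its value 0.0983 h, compound 4 is expected to show a step of an at least 1.4-fold higher number from compound 1 to compound 4 (0.17 log units; that floor lies within the scatter). The estimate for compound 4 in this assay is 0.1 h, with a range from 0.05 h to 0.25 h.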

Compound 4, half-life: < 0.0667 h
Compound 4: only a limit was reported (the forecaster's own chance of this, stated with the estimate: 35%); middle value at least 1.4-fold (0.17 log units) away from the limit.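

In this assay compound 4 gives only a limit of the assay, not a number, as compound 1 does, so the step between them cannot be read. Exchanging 2-amino-1,3-thiazol-5-yl for 4-methyl-1H-imidazol-2-yl on this saturated chain carbon gives an at least 1.4-fold lower number from compound 3 to compound 4 (0.16 log units; that floor lies within the scatter), so the earlier floor seen with compound 3 does not clearly carry over to this second aromatic ring, yet the two rings are not separated beyond the scatter. The limit now holds a larger share of the set: the limit of < 0.0667 h in this assay, at which 2 of the 4 values shown sit.

Going by these compounds, how far compound 1 and compound 4 actually differ stays unknown. Also open, on these data alone, is how an imidazol-2-yl without its methyl, a simple amine or a carboxylic acid on this carbon would read out.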